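The source may hold more compounds than are shown below. What is called first, only, known or untested is meant among the compounds shown, and "the series" means these compounds.

Measured in a functional assay on Hs 683 cells (Homo sapiens) for inhibition, read by MTT assay, with a stated time of 72 h; a higher number here means a weaker inhibitor of growth, a lower number a stronger inhibitor of growth
- compound 1 `CCOC(=O)/C=C/C1=CC[C@H]2C(C)(C)CCC[C@]2(C)[C@H]1C=O` gives 29000 nM
- compound 2 `COC(=O)/C=C/C=C/C1=CC[C@H]2C(C)(C)CCC[C@]2(C)[C@H]1C=O` gives 12000 nM

Of these two, compound 2 has the lower number and is therefore the stronger inhibitor of growth. The unmeasured compound 3 `CC1(C)CCC[C@]2(C)[C@@H](C=O)C(/C=C/C#N)=CC[C@@H]12` keeps the shared core and differs from compound 2 in one group (cyano in place of 2-(methoxycarbonyl)ethenyl on a double-bonded chain carbon bound to a double-bonded chain carbon): cyano in place of 2-(methoxycarbonyl)ethenyl on a double-bonded chain carbon bound to a double-bonded chain carbon. For the measured compounds named here, only one measured step bears on this change, a 2.4-fold lower number from compound 1 to compound 2 (0.38 log units; beyond the scatter) with 2-(methoxycarbonyl)ethenyl in place of ethoxycarbonyl. That step was modest but beyond the scatter. Going by the values given here, the same group now leaves, although no measured compound carries cyano, so any forecast is uncertain. For compound 3 a modest step toward a higher number is expected in this assay (a 2.1-fold higher number from compound 2 to compound 3 (0.32 log units; beyond the scatter)), meaning weaker growth inhibition. Compound 3 is estimated at 25000 nM with an expected range (10000 nM to 60000 nM).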

Compound 3, concentration for 50% growth inhibition: 28000 nM
Estimate against measurement, compound 3: 1.1-fold (0.05 log units) below; measured number inside the range.
By their numbers in this assay, from the lowest: compound 2; then compounds 3 and 1 (each within the scatter of the next).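

In this assay, cyano in place of 2-(methoxycarbonyl)ethenyl gives a 2.3-fold higher number from compound 2 to compound 3 (0.37 log units; beyond the scatter) and so takes away the advantage that compound 2 held over compound 1. Cyano in place of ethoxycarbonyl gives a 1.0-fold lower number from compound 1 to compound 3 (0.02 log units; within the scatter) and leaves those two compounds indistinguishable, so among the three groups tried on this double-bonded chain carbon, only 2-(methoxycarbonyl)ethenyl sets its compound apart. Nothing available explains this difference.

Compound 2 differs from compound 1 in both the length of its chain and its ester, and the compounds shown cannot separate those two changes. Also open, going by these compounds, is how a carboxylic acid, an amine or a longer chain in this place would compare with 2-(methoxycarbonyl)ethenyl.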